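Taking the isopropyl group off the amide nitrogen

A few compounds are considered here, and "the series" means these few. Any claim that something is new, unique, unknown or untested is made for them only; others in the source may bear on it.

Among the compounds with values here, in a functional assay for inhibition, with Homo sapiens as the target (a lower number here means a stronger inhibitor, a higher number a weaker inhibitor), compound 2 `CCCc1c(OCCCOc2ccc(C(=O)NC(C)C)c(OC)c2CCC)ccc2c1OC(C(=O)O)CC2` gives 0.11 nM, the only readable number so far. Compound 1 `CCCc1c(OCCCOc2ccc(C(=O)N(C)C)c(OC)c2CCC)ccc2c1OC(C(=O)O)CC2` gives < 0.14 nM, and this value is a limit of the assay, not a number.

Compound 3 `CCCc1c(OCCCOc2ccc(C(N)=O)c(OC)c2CCC)ccc2c1OC(C(=O)O)CC2` differs from compound 2 by hydrogen in place of isopropyl on an amide-type nitrogen. The isopropyl group leaves and no carbon group takes its place.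

Within the data shown here, one measured step bears on this change, a step that the limit leaves unreadable from compound 1 to compound 2. It alters the groups on the amide-type nitrogen too, but it gives no size to carry over. Among the measured compounds shown here, the expectation therefore rests on compound 2 at 0.11 nM and on the structural change alone, with no measured precedent for losing the whole group. A slight drift toward weaker inhibition is expected in this assay, but nothing beyond the scatter. The expected change is a 1.6-fold higher number from compound 2 to compound 3 (0.21 log units; within the scatter). For compound 3 the estimated value is 0.18 nM, with an expected range of 0.07 nM to 0.6 nM.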

Compound 3, half-maximal inhibitory concentration: 2.7 nM
Compound 3: the middle estimate sits 15-fold (1.18 log units) below what was measured; measured number outside the range, above it.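

In this assay, within the data shown here, the amide-type nitrogen proves to be a sensitive place: hydrogen in place of isopropyl gives a 25-fold higher number from compound 2 to compound 3 (1.39 log units; beyond the scatter), a large loss that the earlier compounds could not reveal. Amino in place of dimethylamino points the same way, with an at least 19-fold higher number from compound 1 to compound 3 (1.28 log units; beyond the scatter), so among these three compounds both of those with carbon groups on the nitrogen give lower numbers than compound 3, which has none, and no compound shown goes against this. Compound 1 stands at a limit of the assay, not a number, so the step from compound 1 to compound 2 cannot be read and the isopropyl and dimethyl amides cannot be ranked against each other: the limit of < 0.14 nM in this assay, at which 1 of the 3 values shown sits.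

The compounds shown leave open whether a single methyl or ethyl group on the nitrogen is enough to bring the number back down, or whether the low values need a group the size of isopropyl. Also open, as far as these compounds go, is how far the nitrogen accepts a longer chain such as n-butyl, a cyclic amine such as pyrrolidine, or a carboxylic acid in place of the whole amide.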